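Swapping the aryl group on the shared core of compound 1

The source may report more compounds than this note shows. Statements on the series, on what has been measured and on what is new or still open speak of the compounds shown alone.

Compound 1 `Oc1c(C(Nc2ccccn2)c2ccccc2Cl)ccc2cccnc12` and compound 2 `Cc1ccnc(NC(c2ccc(F)cc2)c2ccc3cccnc3c2O)c1` share a core. In an assay for inhibition of protein disulfide-isomerase (Homo sapiens), with a stated time of 1 h (on this read-out higher numbers stand for weaker inhibition and lower numbers for stronger inhibition), compound 1 gives 500 nM, the higher of the two numbers, while compound 2 gives 140 nM, a gap beyond the usual scatter. Compound 3 `Cc1ccc(C(Nc2ccccn2)c2ccc3cccnc3c2O)cc1` carries 4-methylphenyl in place of 2-chlorophenyl on a saturated chain carbon bound to an aromatic carbon and a nitrogen on an aromatic ring. Among the measured compounds shown here, no measured pair shows this change, so a small step toward a lower number, possibly no more than the scatter, is expected a 1.7-fold lower number from compound 1 to compound 3 (0.22 log units; within the scatter) in this assay. For compound 3 the estimated value in this assay is 300 nM, expected to lie between 100 nM and 900 nM.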

Compound 3, half-maximal inhibitory concentration: 460 nM
Estimate against measurement, compound 3: 1.5-fold (0.19 log units) below; the range from low to high includes it.
By their numbers in this assay, from the lowest: compound 2; then compounds 3 and 1 (each within the scatter of the next).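

In this assay, 4-methylphenyl in place of 2-chlorophenyl on a saturated chain carbon bound to an aromatic carbon and a nitrogen on an aromatic ring gives a 1.1-fold lower number from compound 1 to compound 3 (0.04 log units; within the scatter). Among the compounds shown here, this is the first comparison here that differs in one place, and on this read-out the two aryl groups cannot be told apart at this position. No other measurement bears on this result.

From the compounds shown here alone, whether an amine or a carboxylic acid on the phenyl ring at this position would move the number stays open. Compound 2 differs from compound 3 in more than one place, so its value cannot be tied to any single change.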